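A few compounds are considered here, and "the series" means these few. Any claim that something is new, unique, unknown or untested is made for them only; others in the source may bear on it.

Compound 1 `CN(c1ncco1)c1cnc(NCc2c(F)ccc3c2CCO3)n2cnnc12` is compared with compound 2 `Cc1nccn1-c1cnc(NCc2c(F)ccc3c2CCO3)c2cn[nH]c(=O)c12` and compound 3 `CC(=O)N1CCC(c2cnc(NCc3c(F)ccc4c3CCO4)c3cn[nH]c(=O)c23)CC1` in an ADME assay on microsomes from liver (Homo sapiens) for metabolic stability, read by LC-MS, using NADPH, with stated times of 5 min and 30 min, tested at 1 uM; a higher number here means faster removal of the compound, a lower number slower removal. In this assay compound 1 gives 11 mL.min-1.g-1, the second highest of the three numbers; compound 2 gives 8 mL.min-1.g-1, within the scatter of compound 1, while compound 3 gives 207 mL.min-1.g-1. Among the measured compounds shown here, the only measured single-point change is a 26-fold higher number from compound 2 to compound 3 (1.41 log units; beyond the scatter), and it lies on a different core and at a different place, so it does not bear on the next step. Compound 4 `CN(C(=O)c1ccccc1)c1cnc(NCc2c(F)ccc3c2CCO3)n2cnnc12` differs from compound 1 by benzoyl in place of 1,3-oxazol-2-yl on a nitrogen on an aromatic ring. For the measured compounds named here, no measured step covers such a change, so the expectation rests on compound 1 alone. A modest step upward is expected, a 2.3-fold higher number from compound 1 to compound 4 (0.36 log units; beyond the scatter). Compound 4 is estimated at 25 mL.min-1.g-1, with a range from 8 mL.min-1.g-1 to 80 mL.min-1.g-1.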

Compound 4, intrinsic clearance in microsomes: > 300 mL.min-1.g-1
Compound 4 ended at the assay's limit; the forecaster's own chance of this, stated with the estimate: 5%; at least 12-fold (1.07 log units) between middle value and limit.
By their numbers in this assay, from the lowest: compounds 2 and 1 (each within the scatter of the next); then compound 3. At a limit, above all of these: compound 4.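

In this assay, the group on this nitrogen proves decisive on the shared core: benzoyl in place of 1,3-oxazol-2-yl gives an at least 27-fold higher number from compound 1 to compound 4 (1.43 log units; beyond the scatter). Compound 4 stands at a limit of the assay, so the true size of this step stays unknown: the limit of > 300 mL.min-1.g-1 in this assay, at which 1 of the 4 values shown sits.

The compounds shown leave open whether the carbonyl or the carbon-only aromatic ring of the benzoyl goes with this step. An acetyl group or a benzyl group on the same nitrogen would separate the two.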